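A few compounds are considered here, and "the series" means these few. Any claim that something is new, unique, unknown or untested is made for them only; others in the source may bear on it.

Measured so far:
compound 1, `COc1ccc(S(=O)(=O)c2cnc3c(F)cccc3c2-c2ccc(Cl)cc2)cc1`: 1.05 mL/min
compound 2, `O=S(=O)(c1ccc(F)c(Cl)c1)c1cnc2c(F)cccc2c1-c1ccc(Cl)cc1`: 0.01 mL/min

For the measured compounds named here, compound 2 stands lowest of the two numbers in an ADME assay on microsomes from liver (Homo sapiens) for metabolic stability, tested at 2.5 uM; a lower number here means slower removal, a higher number faster removal of the compound; its nearest neighbour is compound 1, and the change a 110-fold lower number from compound 1 to compound 2 (2.02 log units; beyond the scatter) is the only measured step. Compound 3 is `Cc1ccc(S(=O)(=O)c2cnc3c(F)cccc3c2-c2ccc(Cl)cc2)cc1F`; (3-fluoro-4-methylphenyl in place of 3-chloro-4-fluorophenyl on a sulfonyl sulfur). That single step bears on it only indirectly: it shows that the group on the sulfonyl sulfur can move this assay a great deal, while no result yet exists for 3-fluoro-4-methylphenyl. A rise from compound 2 is expected, though smaller than the measured step, estimated as a 10-fold higher number from compound 2 to compound 3 (1.00 log units; beyond the scatter). Compound 3 is expected to give 0.1 mL/min (range 0.02 mL/min to 0.6 mL/min).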

Compound 3, intrinsic clearance in a liver preparation (reported as CLH), per the amount of preparation that the assay uses: 2.2 mL/min
Estimate against measurement, compound 3: 22-fold (1.34 log units) below; measured number outside the range, above it.
By their numbers in this assay, from the lowest: compound 2; then compound 1; then compound 3.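

In this assay, a swap between two groups of equal heavy-atom count on the sulfonyl sulfur gives a 220-fold higher number from compound 2 to compound 3 (2.34 log units; beyond the scatter), so 3-fluoro-4-methylphenyl does not retain the low number seen with 3-chloro-4-fluorophenyl. The other step, a 2.1-fold higher number from compound 1 to compound 3 (0.32 log units; beyond the scatter), is far smaller, leaving 3-chloro-4-fluorophenyl alone at the low end among these three groups. Nothing available here accounts for these differences. Still open, going by these compounds, is which part of 3-chloro-4-fluorophenyl carries the low number, and where a morpholine or a carboxylic acid on the sulfonyl sulfur would fall.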